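The compounds below may be only part of what the source reports. "The series", "measured", "known", "first", "only" and "open" are said of these compounds alone.

In a physicochemical assay for lipophilicity, measured as octanol-water partition (on this read-out lower numbers stand for lower lipophilicity and higher numbers for higher lipophilicity), compound 3 (`CCCCCCCCc1cn(CC=C(C)C)nn1`) stands highest of the three measured at 4.92, above compound 1 (`CCCCCc1cn(CC=C(C)C)nn1`) at 3.46 and compound 2 (`COC(=O)c1cn(CC=C(C)C)nn1`) at 1.3. Compound 4 (`CCCc1cn(CC=C(C)C)nn1`) has hydrogen in place of pentyl on a saturated chain carbon, three bonds along the chain from an aromatic carbon. The closest measured change is the large a number 1.46 log units higher from compound 1 to compound 3 (beyond the scatter), where propyl replaced hydrogen. The new change runs the opposite way and removes the longer pentyl, so a somewhat larger step is expected. The large a number 2.16 log units lower from compound 1 to compound 2 (beyond the scatter) involves a different group and bears only loosely. The expected change is a number 2.42 log units lower from compound 3 to compound 4 (beyond the scatter). Compound 4 is estimated at 2.5, with an expected range of 2.2 to 2.8.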

Compound 4, partition coefficient: 2.47
Beside the measured number, compound 4's estimate is 0.03 log units above it, and the stated range covers the measured number.
By their numbers in this assay, from the lowest: compound 2; then compound 4; then compound 1; then compound 3.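

In this assay, the chain series now reads in both directions at this place: removing pentyl gives the larger fall (a number 2.45 log units lower from compound 3 to compound 4 (beyond the scatter)) and removing ethyl the smaller (a number 0.99 log units lower from compound 1 to compound 4 (beyond the scatter)), and none of these three compounds goes against that order. Propyl in place of methoxycarbonyl on an aromatic carbon still gives a clear rise (a number 1.17 log units higher from compound 2 to compound 4 (beyond the scatter)). No measured evidence accounts for these steps. The compounds shown leave open whether a chain longer than that of compound 3 keeps the number rising, and what an amine or a carboxylic acid on the chain would give.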